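The compounds below may be only part of what the source reports. "The series", "measured", "known", "first", "only" and "open" are said of these compounds alone.

Compound 1 `CO[C@@]12CCN(C)C[C@H]1[C@H](c1ccc(Cl)cc1)C(C#N)=C(N)O2` and compound 2 `CCN1CC[C@@]2(OC)OC(N)=C(C#N)[C@@H](c3ccc(Cl)cc3)[C@@H]2C1` share one core and differ only in the group on the ring amine nitrogen. In a functional assay on trachea (Cavia porcellus) (on this read-out lower numbers stand for stronger inhibition and higher numbers for weaker inhibition), compound 1 gives 10500 nM and compound 2 gives 14900 nM. Of these two numbers compound 2 holds the higher one, yet the step between them, a 1.4-fold higher number from compound 1 to compound 2 (0.15 log units; within the scatter), sits within the scatter, so the two cannot be told apart. Compound 3 `CCCN1CC[C@@]2(OC)OC(N)=C(C#N)[C@@H](c3ccc(Cl)cc3)[C@@H]2C1` carries the next change of the same kind: methyl in place of hydrogen on a saturated chain carbon, two bonds along the chain from an amine nitrogen in a ring. Going by the values given here, the only measured step that bears on it is a 1.4-fold higher number from compound 1 to compound 2 (0.15 log units; within the scatter), which did not move this assay beyond the scatter, and that single pair is all the evidence there is. On that basis no step beyond the scatter is expected for compound 3 in this assay. Compound 3 is therefore expected to give about 16000 nM, with a range from 7000 nM to 37000 nM. The step this estimate implies, a 1.1-fold higher number from compound 2 to compound 3 (0.03 log units; within the scatter), is expected to stay within the scatter.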

Compound 3, half-maximal inhibitory concentration: 30300 nM
For compound 3 the middle estimate is 1.9-fold (0.28 log units) below the measured one, and the stated range covers the measured number.
By their numbers in this assay, from the lowest: compounds 1 and 2 (each within the scatter of the next); then compound 3.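

Going from ethyl to propyl on the ring amine nitrogen gives a step that clears the scatter in this assay: the change brings a 2.0-fold higher number from compound 2 to compound 3 (0.31 log units; beyond the scatter) and is modest, while methyl and ethyl at this position could not be told apart. Measured against the methyl group, the propyl group gives a 2.9-fold higher number from compound 1 to compound 3 (0.46 log units; beyond the scatter) and is also modest, so among these three groups only propyl stands apart, on the side of weaker inhibition. Nothing available explains why this position tolerates ethyl but shows a shift with propyl.

The compounds shown leave open whether a longer chain such as butyl would push the number higher still, or whether the shift levels off after propyl. They also leave open how a branched group such as isopropyl, or a plain hydrogen on that nitrogen, would compare.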